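Replacing a Halogenated Aryl Amine with a Methoxyphenyl

The source may hold more compounds than are shown below. What is called first, only, known or untested is meant among the compounds shown, and "the series" means these compounds.

Compound 1 `CNC(=O)c1ccccc1Oc1nc(Nc2ccccc2OC)ncc1Br`: 40500 nM
Compound 2 `CNC(=O)c1ccccc1Oc1nc(Nc2cccc(C)c2)ncc1Br`: 6100 nM
Compound 3 `CNC(=O)c1ccccc1Oc1nc(Nc2ccc(Cl)cc2F)ncc1Br`: 38100 nM

In a functional assay on A549 cells (Homo sapiens) for antiproliferative activity, read by MTT assay, with a stated time of 24 h (on this read-out lower numbers stand for stronger inhibition and higher numbers for weaker inhibition), compound 3 stands second highest of the three, close to compound 1, with a 1.1-fold lower number from compound 1 to compound 3 (0.03 log units; within the scatter), but well apart from compound 2, with a 6.2-fold higher number from compound 2 to compound 3 (0.80 log units; beyond the scatter). Compound 4 `CNC(=O)c1ccccc1Oc1nc(Nc2cccc(OC)c2)ncc1Br` differs from compound 3 in one place: 3-methoxyphenyl in place of 4-chloro-2-fluorophenyl on a nitrogen on an aromatic ring. Among the compounds with values here, the step that bears on this is the one from compound 2 to compound 3, in which a 3-methylphenyl gave way to the same halogenated ring and the number rose. Going back from that ring to a 3-substituted phenyl, now carrying methoxy rather than methyl, is expected to lower the number by a comparable amount, so that for compound 4 the estimated step is a 4.2-fold lower number from compound 3 to compound 4 (0.63 log units; beyond the scatter). Compound 4 is therefore estimated at 9000 nM, within 3500 nM to 30000 nM.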

Compound 4, half-maximal inhibitory concentration: 6230 nM
Estimate against measurement, compound 4: 1.4-fold (0.16 log units) above; low and high end bracket the measured number.
By their numbers in this assay, from the lowest: compounds 2 and 4 (each within the scatter of the next); then compounds 3 and 1 (each within the scatter of the next).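

In this assay the change to 3-methoxyphenyl from 4-chloro-2-fluorophenyl gives a 6.1-fold lower number from compound 3 to compound 4 (0.79 log units; beyond the scatter) and methoxy in place of methyl on an aromatic carbon gives a 1.0-fold higher number from compound 2 to compound 4 (0.01 log units; within the scatter), so these two groups cannot be told apart at this place. The same group also reads differently by where it sits on the ring, as 3-methoxyphenyl in place of 2-methoxyphenyl gives a 6.5-fold lower number from compound 1 to compound 4 (0.81 log units; beyond the scatter) and so separates the two. No evidence at hand explains these steps. As far as these compounds go, it remains open how an amine or a carboxylic acid in place of the methoxy of 3-methoxyphenyl would read.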